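This account rests on a few compounds, and the source may have more. Where it says the series, first, only, none or still open, it means among the compounds named here.

Measured in an ADME assay on RAW264.7 cells (Mus musculus) for cytotoxicity, read by MTT assay, with a stated time of 24 h, in the presence of a further agent that is not named here (on this read-out lower numbers stand for stronger inhibition and higher numbers for weaker inhibition), each value being a limit of the assay:
- compound 1 `CCCCCCOc1ccc(C(O)C2OC(=O)c3c(OC)cc(OC)cc32)cc1`: > 40000 nM
- compound 2 `COc1cc(OC)c2c(c1)C(C(O)c1ccc(OCCOc3ccccc3)cc1)OC2=O`: > 40000 nM
- compound 3 `COc1cc(OC)c2c(c1)C(C(O)c1ccc(OCc3ccc(Cl)cc3)cc1)OC2=O`: > 40000 nM

Compound 3 gives only a limit, > 40000 nM, and no number. It shares that position with the other two compounds: the limit of > 40000 nM in this assay, at which 3 of the 3 values shown sit.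

Compound 4 `COc1cc(OC)c2c(c1)C(C(O)c1ccc(OCc3ccc(Br)cc3)cc1)OC2=O` differs from compound 3 by bromo in place of chloro on an aromatic carbon, para to a large group: bromo in place of chloro on an aromatic carbon. Among the measured compounds shown here, no measured step covers this exchange of halogens. The nearest are those that change the same side chain: a step that the two limits leave unreadable from compound 1 to compound 3, a step that the two limits leave unreadable from compound 2 to compound 3 and a step that the two limits leave unreadable from compound 1 to compound 2. For the measured compounds named here, none of the three has a readable size, so they show only that all three compounds remain at the limit.

From the limit of compound 3, > 40000 nM, no step beyond the scatter is expected in this assay, in either direction. The expected change is a step that the limit leaves unreadable from compound 3 to compound 4. Compound 4 is estimated at 50000 nM, with an expected range from 25000 nM to 100000 nM, and will probably be reported as a limit again.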

Compound 4, half-maximal inhibitory concentration: > 40000 nM
Compound 4: a limit, no number (the forecaster's own chance of this, stated with the estimate: 90%); the middle value is on the limit's open side.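

In this assay, among the compounds shown here, compound 4 gives > 40000 nM, a limit and not a number, so no step from compound 1, compound 2 or compound 3 to compound 4 can be read. The compounds shown leave open whether changing the side chain alters this read-out at all: the limit of > 40000 nM in this assay, at which 4 of the 4 values shown sit.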